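Removing the alkynyl chain from a fused core

The source may hold more compounds than are shown below. What is called first, only, known or untested is meant among the compounds shown, and "the series" means these compounds.

Compound 1, `O=c1nc2oc(CCCCl)c(C#CCCCCCl)c2cn1Cc1cn(-c2ccc(F)cc2)nn1`: 70 nM in an ADME assay on WI-38 cells (Homo sapiens) for antiproliferative activity, read by MTT assay, with a stated time of 72 h; a higher number here means a weaker inhibitor, a lower number a stronger inhibitor
Compound 2, `O=c1nc2oc(CCCCl)c(C#CCCCCl)c2cn1Cc1cn(-c2ccc(Cl)cc2)nn1`: > 100000 nM, which is a limit of the assay and not a number

Compound 1 carries the only number shown here. Compound 2 sits at the limit of > 100000 nM in this assay, at which 1 of the 2 values shown sits. Compound 3, `O=c1nc2oc(CCCCl)cc2cn1Cc1cn(-c2ccc(F)cc2)nn1`, has not been measured in this assay. It differs from compound 1 in one place: hydrogen in place of 6-chlorohex-1-yn-1-yl on an aromatic carbon. The whole chain of six carbons and one chlorine is gone, leaving a bare hydrogen on that aromatic carbon of the shared core. Nothing in the two measured compounds shows the effect of this exact change on its own, so the size of the step rests on the loss of a sizeable group. A step toward weaker inhibition is expected from compound 1 to compound 3 in this assay, well beyond the scatter. Compound 3 is estimated at 5000 nM, with a range of 300 nM to 100000 nM, meaning a step of a 71-fold higher number from compound 1 to compound 3 (1.85 log units; beyond the scatter).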

Compound 3, half-maximal inhibitory concentration: < 10 nM
Compound 3: only a limit was reported (the forecaster's own chance of this, stated with the estimate: 30%); middle value at least 500-fold (2.69 log units) away from the limit.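

Removing the 6-chlorohex-1-yn-1-yl chain from this aromatic carbon does not cost activity in this assay; the number moves toward stronger inhibition, with an at least 7.0-fold lower number from compound 1 to compound 3 (0.84 log units; beyond the scatter). The chain is therefore not needed for activity in this pair, and a bare hydrogen at this place gives the stronger result. Compound 3 sits at a limit of the assay and not at a number, so the step has a known minimum but no known full size: the limit of < 10 nM in this assay, at which 1 of the 3 values shown sits.

The compounds shown do not explain why losing the chain strengthens inhibition, and the data hold no measurement that could separate the triple bond, the chain length or the terminal chlorine as the source. Going by these compounds, it also remains open whether a methyl group, an amine or a shorter alkynyl chain on this carbon would match the hydrogen.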